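This account rests on a few compounds, and the source may have more. Where it says the series, first, only, none or still open, it means among the compounds named here.

Of the compounds shown here, two have been measured so far in an ADME assay (liver) for metabolic stability, with Liver microsome (Homo sapiens) as the target, using microsomes; on this read-out higher numbers stand for a longer-lived compound and lower numbers for a shorter-lived compound: compound 1 `CCc1nc2ccc(Cl)cn2c1C(=O)NCc1ccc(-c2ccc(C#N)cc2)cc1` and compound 2 `CCc1nc2cc(Cl)ccn2c1C(=O)NCc1ccc(-c2ccc(Cl)cc2)cc1`. Compound 1 gives > 2 h, which is a limit of the assay. Compound 2 gives > 2 h, which is also a limit and not an exact number. Compound 3 `CCc1nc2cc(Cl)ccn2c1C(=O)NCc1ccc(N2CC3CCCCC3C2)cc1` keeps the rest of compound 2 but replaces the 4-chlorophenyl on an aromatic carbon, para to a large group: a group of 9 heavy atoms (8 carbon, 1 nitrogen; one five-membered non-aromatic ring with 1 hetero atom, one six-membered non-aromatic ring of carbon only) in place of a group of 7 heavy atoms (6 carbon, 1 chlorine; one six-membered aromatic ring of carbon only), on an aromatic carbon. Going by the values given here, no measured step shows the effect of this change, so only a moderate shortening is expected, the estimated step being an at least 1.3-fold lower number from compound 2 to compound 3 (0.12 log units; that floor lies within the scatter). Compound 3 is estimated at 1.5 h, with an expected range of 0.5 h to 4 h.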

Compound 3, half-life: 0.248 h
Beside the measured number, compound 3's estimate is 6.0-fold (0.78 log units) above it; measured number below the stated range.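

In this assay, the group on an aromatic carbon, para to a large group, clearly matters: replacing the 4-chlorophenyl with the group of two non-aromatic rings gives an at least 8.0-fold lower number from compound 2 to compound 3 (0.90 log units; beyond the scatter). The true size of this step remains unknown, and the printed figure is only a floor because one end of it rests on a limit: the limit of > 2 h in this assay, at which 2 of the 3 values shown sit.

On these data alone, what remains open is which feature of the new group goes with the shorter half-life: its nitrogen, its non-aromatic rings or its size. A morpholine or an unsubstituted phenyl at this place would help separate these possibilities.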